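Trifluoromethyl on the Phenoxy Ring of a Weak Inhibitor

A few compounds are considered here, and "the series" means these few. Any claim that something is new, unique, unknown or untested is made for them only; others in the source may bear on it.

Within the data shown here, compound 2 `CN(Cc1ccc(OCCCN)cc1)c1nc2ccc(Oc3ccccc3)cc2s1` is the stronger of the two compounds measured so far in an assay on cells for inhibition of Voltage-dependent T-type calcium channel subunit alpha-1H (Homo sapiens), read by FLIPR and calcium flux, with stated times of 600 s and 300 s; a higher number here means a weaker inhibitor, a lower number a stronger inhibitor: compound 2 gives 95000 nM, while compound 1 `CN(Cc1ccc(OCCCNC(=N)N)cc1)c1nc2ccc(Oc3ccccc3)cc2s1` gives 498000 nM. Among the measured compounds shown here, the single measured step, a 5.2-fold lower number from compound 1 to compound 2 (0.72 log units; beyond the scatter), concerns only the amine nitrogen at the far end of the side chain, where a group is removed.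

Compound 3 `CN(Cc1ccc(OCCCN)cc1)c1nc2ccc(Oc3cccc(C(F)(F)F)c3)cc2s1` keeps that amine unchanged and alters the phenoxy ring instead: trifluoromethyl in place of hydrogen on an aromatic carbon

For the measured compounds named here, no measured step touches this part of the shared core, so the step between compound 1 and compound 2 offers no guide to it. With nothing comparable among the measured compounds, the expected step in this assay, a 1.4-fold lower number from compound 2 to compound 3 (0.13 log units; within the scatter), is taken to be small, and its direction is uncertain. Compound 3 is therefore estimated at 70000 nM, with a range from 15000 nM to 300000 nM, reflecting that estimate's wide uncertainty.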

Compound 3, half-maximal inhibitory concentration: 239000 nM
For compound 3 the middle estimate is 3.4-fold (0.53 log units) below the measured one, within the range that was stated.
By their numbers in this assay, from the lowest: compound 2; then compound 3; then compound 1.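

In this assay the phenoxy ring now has a measured change of its own, separate from the amine at the end of the side chain: with that amine unchanged, trifluoromethyl in place of hydrogen gives a 2.5-fold higher number from compound 2 to compound 3 (0.40 log units; beyond the scatter), a modest step toward weaker inhibition. Among these compounds, this shows that the inhibition read here responds to a change on the phenoxy ring as well as to one on the amine nitrogen, the only place the earlier pair could speak to. For this one substituent at this one place, the change does not improve on the unsubstituted phenoxy ring of compound 2, and nothing available here explains the step.

A single substituent cannot show whether the loss belongs to trifluoromethyl itself or to any group at this place, so a methyl, a methoxy or a chlorine atom on the same carbon would be needed to separate the two. From the compounds shown here alone, it also remains open whether trifluoromethyl at another carbon of the ring would give a similar step, or whether any group on this ring can lower the number below that of compound 2.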